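This account rests on a few compounds, and the source may have more. Where it says the series, first, only, none or still open, it means among the compounds named here.

Measured compounds and their read-outs:
Compound 1, `CCOC(=O)[C@H](CCC(=O)O)NC(=O)c1ccc(CNc2nc3cc(N)cc(N)c3nc2-c2ccccc2)cc1`, gives a limit, < 100000 nM.
Compound 2, `Nc1cc(N)c2nc(-c3ccccc3)c(NCc3ccc(Cl)c(Cl)c3)nc2c1`, gives 29500 nM.
Compound 3, `CCOC(=O)[C@H](CCC(=O)O)NC(=O)c1ccc(Oc2nc3cc(N)cc(N)c3nc2-c2ccccc2)cc1`, gives a limit, < 100000 nM.

Within the data shown here, in a functional assay on IGROV-1 cells (Homo sapiens) for inhibition, read by sulforhodamine B assay, with a stated time of 48 h (on this read-out higher numbers stand for lower toxicity in this test and lower numbers for higher toxicity in this test), compound 2 is the only compound of the three with an actual number. For compound 1 the read-out is a limit of the test and not a number. For compound 3 the read-out is likewise a limit. Compound 2 therefore stands alone as the one quantified point, set against (the limit of < 100000 nM in this assay, at which 2 of the 3 values shown sit). Among the measured compounds shown here, no pair of measured compounds differs in only one place, so no measured step is available to anchor the next change.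

Compound 4, `COc1ccc(CNc2nc3cc(N)cc(N)c3nc2-c2ccccc2)cc1`, has not yet been measured. It differs from compound 2 in one place: 4-methoxyphenyl in place of 3,4-dichlorophenyl on a saturated chain carbon bound to a nitrogen on an aromatic ring. For the measured compounds named here, with no comparable measured step in this set, the expectation can rest only on the number for compound 2 and on the nature of the exchange. The step is expected to be modest, toward higher numbers, that is toward lower toxicity in this test, and of a size near the edge of the usual scatter rather than clearly beyond it. For compound 4 the estimate in this assay is 50000 nM, within a range from 15000 nM to 100000 nM. That estimate corresponds to an expected step of a 1.7-fold higher number from compound 2 to compound 4 (0.23 log units; within the scatter).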

Compound 4, concentration lethal to 50% of the cells: 56200 nM
The estimate for compound 4 lay 1.1-fold (0.05 log units) below the measured number; measured number inside the range.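

In this assay, 4-methoxyphenyl in place of 3,4-dichlorophenyl on a saturated chain carbon bound to a nitrogen on an aromatic ring gives a 1.9-fold higher number from compound 2 to compound 4 (0.28 log units; within the scatter). Among these compounds, this is the first one-place comparison, and because it lies within the usual scatter, the read-out does not separate these two groups at this position, even though they share no substituent. Compound 2 and compound 4 are now the only quantified points, and the other read-outs shown remain limits and not numbers: the limit of < 100000 nM in this assay, at which 2 of the 4 values shown sit.

Still open, going by these compounds, is whether any group at this position can move the number beyond the scatter, for example an unsubstituted phenyl, a phenyl carrying a single chlorine, or a phenyl carrying an amine or a carboxylic acid. Also open, on these data alone, is whether a longer chain between the nitrogen and the aromatic ring would leave the read-out as it stands, or whether the 3,4-dichlorobenzyl and 4-methoxybenzyl result holds only for this chain.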